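The source may hold more compounds than are shown below. What is called first, only, known or untested is meant among the compounds shown, and "the series" means these compounds.

Compound 2 `CCCCNc1nc(N)nc2c1CN(Cc1cccnc1)CC2` holds the lower of the two numbers obtained so far in an assay on HEK293 cells for agonist activity at Toll-like receptor 8 (Homo sapiens), read by a luciferase reporter, with a stated time of 6 h; on this read-out lower numbers stand for an effect already at smaller amounts and higher numbers for an effect only at larger amounts of compound: compound 2 gives 0.13 uM, while compound 1 `CCCCNc1nc(N)nc2c1CN(C(C)=O)CC2` gives 0.5 uM. Within the data shown here, the single step measured between them, a 3.8-fold lower number from compound 1 to compound 2 (0.59 log units; beyond the scatter), is the only comparison available in this assay. Compound 3 `CCCCNc1nc(N)nc2c1CN(Cc1ccco1)CC2` keeps the core of compound 2 and differs from it in one place: furan-2-yl in place of pyridin-3-yl on a saturated chain carbon bound to an amine nitrogen in a ring. Among the measured compounds shown here, no measured step exchanges one aromatic ring for another at this carbon. The step from compound 1 to compound 2 replaces an acetyl with an arylmethyl group, so it bears on the presence of the arylmethyl, which compound 3 retains, and not on the identity of the aromatic ring. The counted difference shows an aromatic ring with a hetero atom and a hydrogen-bond acceptor on each side of the exchange, with no change in donors or in charge. Against this background, compound 3 is expected to give a number close to that of compound 2 in this assay, with a 1.5-fold higher number from compound 2 to compound 3 (0.19 log units; within the scatter) as the estimated step, not beyond the scatter. The estimate for compound 3 in this assay is 0.2 uM, with a range from 0.06 uM to 0.6 uM.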

Compound 3, minimum effective concentration: 0.08 uM
Beside the measured number, compound 3's estimate is 2.5-fold (0.40 log units) above it; low and high end bracket the measured number.
By their numbers in this assay, from the lowest: compounds 3 and 2 (each within the scatter of the next); then compound 1.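

Among these compounds, at the saturated chain carbon bound to an amine nitrogen in a ring, the first exchange of one aromatic ring for another, furan-2-yl in place of pyridin-3-yl, gives a 1.6-fold lower number from compound 2 to compound 3 (0.21 log units; within the scatter) in this assay and so does not separate a five-membered aromatic ring with an oxygen from a six-membered one with a nitrogen on this read-out. The exchange of acetyl for (furan-2-yl)methyl on the amine nitrogen in a ring gives a 6.3-fold lower number from compound 1 to compound 3 (0.80 log units; beyond the scatter) and lies beyond the scatter, as does the earlier 3.8-fold lower number from compound 1 to compound 2 (0.59 log units; beyond the scatter) for (pyridin-3-yl)methyl, so the lower number against the acetyl compound now holds for two different arylmethyl groups and no longer rests on a single ring. No measurement on hand offers an explanation for either step.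

The compounds shown leave open whether a hetero atom in the ring matters at all, a question that a plain phenyl on the same saturated chain carbon would address. As far as these compounds go, it is also open whether an aromatic ring is needed there, which a cyclohexyl group in that place would test.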